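Heteroaryl urea series: expectation for compound 3

The compounds below may be only part of what the source reports. "The series", "measured", "known", "first", "only" and "open" are said of these compounds alone.

Measured so far:
compound 1 `O=C(Nc1noc2ccccc12)N1CCN(Cc2cccc(Oc3ccc(Cl)cc3)c2)CC1` — 10 nM
compound 2 `O=C(Nc1noc2cccnc12)N1CCN(Cc2cccc(Oc3ccc(Cl)cc3)c2)CC1` — 13 nM

Going by the values given here, in an assay on isolated protein for inhibition of Fatty-acid amide hydrolase 1 (Homo sapiens), with a stated time of 60 min (on this read-out higher numbers stand for weaker inhibition and lower numbers for stronger inhibition), compound 2 gives 13 nM, the highest of the two numbers; the only measured step, a 1.3-fold higher number from compound 1 to compound 2 (0.11 log units; within the scatter), lies within the scatter, so compound 1 and compound 2 cannot be ordered.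

Compound 3 `O=C(Nc1cn2ccccc2n1)N1CCN(Cc2cccc(Oc3ccc(Cl)cc3)c2)CC1` differs from compound 2 by a group of 9 heavy atoms (7 carbon, 2 nitrogen; one five-membered aromatic ring with 2 hetero atoms, one six-membered aromatic ring with 1 hetero atom) in place of a group of 9 heavy atoms (6 carbon, 2 nitrogen, 1 oxygen; one five-membered aromatic ring with 2 hetero atoms, one six-membered aromatic ring with 1 hetero atom), on an amide-type nitrogen. Among the compounds with values here, the one step that bears on it, a 1.3-fold higher number from compound 1 to compound 2 (0.11 log units; within the scatter), altered the same group on the amide-type nitrogen and stayed within the scatter, yet no measured step exchanges one such ring system for another of different composition, so little weight can rest on it. A small rise in this assay, or none beyond the scatter, is expected. Compound 3 is estimated at 30 nM, range 10 nM to 100 nM, an expected step of a 2.3-fold higher number from compound 2 to compound 3 (0.36 log units; beyond the scatter).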

Compound 3, half-maximal inhibitory concentration: > 10000 nM
Compound 3 was reported as a limit; the forecaster's own chance of this, stated with the estimate: 5%; at least 330-fold (2.52 log units) between middle value and limit.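

In this assay the result for compound 3 is a limit of the assay: the limit of > 10000 nM in this assay, at which 1 of the 3 values shown sits.

The group on the amide-type nitrogen, earlier changed only within the scatter, now gives large steps: an at least 760-fold higher number from compound 2 to compound 3 (2.88 log units; beyond the scatter), and an at least 1000-fold higher number from compound 1 to compound 3 (3.00 log units; beyond the scatter). Both groups have 9 heavy atoms and the same ring sizes, so these features alone do not preserve the read-out at this position.

The compounds shown do not separate the loss of oxygen from the different arrangement of the ring atoms. On these data alone, how a single phenyl or pyridine ring would read on this nitrogen remains open.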